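A Fluorine-Bearing Ring Replaces a Methoxy-Methyl Ring

The source may report more compounds than this note shows. Statements on the series, on what has been measured and on what is new or still open speak of the compounds shown alone.

Of the compounds shown here, three sharing one core have been tested in a functional assay on SJSA-1 cells (Homo sapiens) for inhibition, read by CCK-8 assay, with a stated time of 72 h, tested at 1 uM; on this read-out lower numbers stand for less inhibition and higher numbers for more inhibition at the one concentration tested (going by the name of the read-out). Compound 1 `COc1ccc(C)cc1N1C(=O)CSC1c1cccc(C(=O)NCCCCc2ccccc2)c1` gives 79% in this assay, which places it second highest of the three measured numbers. Compound 3 `O=C(NCCCCc1ccccc1)c1cccc(C2SCC(=O)N2c2cccc(F)c2)c1` gives 80%, and the step of a number 1 percentage points higher from compound 1 to compound 3 (within the scatter) lies within the scatter. Compound 2 `COc1ccc(OC)c(N2C(=O)CSC2c2cccc(C(=O)NCCCCc3ccccc3)c2)c1` gives 48%, and the step of a number 31 percentage points lower from compound 1 to compound 2 (beyond the scatter) is a large fall, so compound 1 is clearly ahead of compound 2 but cannot be separated from compound 3.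

The next compound, compound 4 `O=C(NCCCCc1ccccc1)c1cccc(C2SCC(=O)N2c2ccccc2F)c1`, has not yet been measured. It differs from compound 1 in one place: 2-fluorophenyl in place of 2-methoxy-5-methylphenyl on an amide-type nitrogen in a ring.

Among the measured compounds shown here, two measured steps bear on this change. The step of a number 1 percentage points higher from compound 1 to compound 3 (within the scatter) shows that swapping the same 2-methoxy-5-methylphenyl group for a 3-fluorophenyl group left the inhibition unchanged. The step of a number 32 percentage points higher from compound 2 to compound 3 (beyond the scatter) shows that a fluorophenyl group in this position scored far above the 2,5-dimethoxyphenyl group. Both point to the number in this assay staying level or higher with a fluorophenyl group here, though only the 3-fluorophenyl case has been seen, so the 2-fluorophenyl outcome rests on a single analogy.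

Compound 4 is therefore expected to sit close to compound 1, with an estimated step of a number 2 percentage points lower from compound 1 to compound 4 (within the scatter), within the scatter. The estimated value for compound 4 is 77%, expected to fall between 62% and 90%.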

Compound 4, a percentage reported as inhibition, at one concentration (the size of the read-out at that concentration, not a potency): 80%
Beside the measured number, compound 4's estimate is 3 percentage points below it; measured number inside the range.
By their numbers in this assay, from the lowest: compound 2; then compounds 1, 3 and 4 (each within the scatter of the next).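

In this assay, among the compounds shown here, the result gives no change at the digits printed from compound 3 to compound 4 (within the scatter), so on this amide-type nitrogen in a ring, the 2-fluorophenyl and 3-fluorophenyl groups cannot be told apart, which the single fluorinated compound measured earlier could not show. The step of a number 1 percentage points higher from compound 1 to compound 4 (within the scatter) adds a second fluorinated group that stands level with the 2-methoxy-5-methylphenyl group, even though the entering group is smaller by the count of heavy atoms and has no hydrogen-bond acceptor. For the compounds shown here, the step of a number 32 percentage points higher from compound 2 to compound 4 (beyond the scatter) shows that the large gap to the 2,5-dimethoxyphenyl group of compound 2 is not tied to one fluorophenyl group, and compound 2 remains the one compound that goes against the level shared by the other three.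

No measurement here bears on what lies behind these numbers. Still open, as far as these compounds go, is whether an unsubstituted phenyl ring, a pyridine ring or a phenyl ring carrying an amine on this nitrogen would keep the level of compounds 1, 3 and 4 or fall towards compound 2.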